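Swapping the aryl group on the ring nitrogen

The source may report more compounds than this note shows. Statements on the series, on what has been measured and on what is new or still open speak of the compounds shown alone.

Measured compounds:
Compound 1 `COc1cc(-c2ncnn2-c2ccccc2)cc(OC)c1OC` gives > 10000 nM in a functional assay on HeLa cells (Homo sapiens) for antiproliferative activity, read by MTT assay, with a stated time of 72 h (a higher number here means a weaker inhibitor, a lower number a stronger inhibitor), which is a limit of the assay.
Compound 2 `COc1cc(-c2ncnn2-c2ccc(Cl)c(Cl)c2)cc(OC)c1OC` gives > 10000 nM, again a limit.
Compound 3 `COc1ccc(-c2ncnn2-c2cc(OC)c(OC)c(OC)c2)cc1` gives 280 nM.

Compound 2 thus stands at the limit where two of the three values sit (the limit of > 10000 nM in this assay, at which 2 of the 3 values shown sit), so no number is known for it. Among the measured compounds shown here, the only measured step, a step that the two limits leave unreadable from compound 1 to compound 2, has no readable size. Compound 4 `COc1cc(-c2ncnn2-c2ccc(N)cc2)cc(OC)c1OC` differs from compound 2 by 4-aminophenyl in place of 3,4-dichlorophenyl on an aromatic nitrogen. For the measured compounds named here, no measured step mirrors this change, so its size cannot be read from the data; compound 3 only shows that a number can be reached with this core. Compound 4 is expected to give 6000 nM, between 1200 nM and 30000 nM. The expected step of an at least 1.6-fold lower number from compound 2 to compound 4 (0.22 log units; that floor lies within the scatter) is therefore a guess toward modest activity.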

Compound 4, half-maximal inhibitory concentration: > 10000 nM
Compound 4: a limit, no number; the forecaster's own chance of this, stated with the estimate: 40%; at least 1.6-fold (0.22 log units) between middle value and limit.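

Compound 4, like compound 1 and compound 2, sits at a limit and not at a number, and no step among these three can be read: the limit of > 10000 nM in this assay, at which 3 of the 4 values shown sit.

Still open, on these data alone, is which group on the aromatic nitrogen, with the core of compound 1, would give a number.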